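Extending the amine-bearing chain toward compound 4

The source may hold more compounds than are shown below. What is called first, only, known or untested is meant among the compounds shown, and "the series" means these compounds.

Compound 2 `CCN(CC)CCCCOc1ccc(/C=C/C(=O)Nc2ccccc2)cc1OC` gives 1.59 in a physicochemical assay for lipophilicity, using the shake flask method, measured as octanol-water partition, at pH 7.4; on this read-out higher numbers stand for higher lipophilicity and lower numbers for lower lipophilicity. Compound 1 `COc1cc(/C=C/C(=O)Nc2ccccc2)ccc1OCCCN(C)C` gives 1.55 and compound 3 `COc1cc(/C=C/C(=O)Nc2ccccc2)ccc1OCCCCCCN1CCCC1` gives 1.76 in this assay, so the steps of a number 0.04 log units higher from compound 1 to compound 2 (within the scatter) and a number 0.17 log units higher from compound 2 to compound 3 (within the scatter) both lie within the scatter, and compound 2 sits indistinguishably among the three. Compound 4 `CCN(CC)CCCCCCCCCCOc1ccc(/C=C/C(=O)Nc2ccccc2)cc1OC` differs from compound 2 by 6-(diethylamino)hexyl in place of diethylamino on a saturated chain carbon, four bonds along the chain from an oxygen on an aromatic ring. Going by the values given here, no measured step adds chain alone; the nearest comparison, a number 0.21 log units higher from compound 1 to compound 3 (within the scatter), also stays within the scatter. The chain entering compound 4 is longer than any change measured so far, so a step upward beyond the scatter is expected in this assay, estimated as a number 0.91 log units higher from compound 2 to compound 4 (beyond the scatter). Compound 4 is accordingly expected at 2.5, within a range of 1.8 to 3.3.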

Compound 4, partition coefficient: 1.83
The estimate for compound 4 lay 0.67 log units above the measured number, and the stated range covers the measured number.
By their numbers in this assay, from the lowest: compounds 1, 2, 3 and 4 (each within the scatter of the next).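

At this place, on a saturated chain carbon, four bonds along the chain from an oxygen on an aromatic ring, 6-(diethylamino)hexyl in place of diethylamino gives in this assay a number 0.24 log units higher from compound 2 to compound 4 (within the scatter), so even this much added chain does not separate the two compounds. The comparison with the pyrrolidin-1-yl compound gives a number 0.07 log units higher from compound 3 to compound 4 (within the scatter), and all four compounds now remain within the scatter of their neighbours. Nothing measured here offers an explanation for this result. The compounds shown leave open whether a still longer chain would produce a step beyond the scatter. They also leave open whether a morpholine or a piperazine in place of the diethylamino group would do so.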